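Bromine on the Anilino Ring: Compound 2 to Compound 3

This account rests on a few compounds, and the source may have more. Where it says the series, first, only, none or still open, it means among the compounds named here.

Compound 1, `Cc1ccc(NC2=CC(=O)c3c(nc4n3[C@H]3OC[C@@H](O)[C@H]3OC4)C2=O)cc1C`: 4090 nM
Compound 2, `O=C1C=C(Nc2ccccc2)C(=O)c2c1nc1n2[C@H]2OC[C@@H](O)[C@H]2OC1`: 4970 nM

Two anilino-bearing compounds on a shared core have been measured in a functional assay on ECa-109 cells for inhibition, with ECa-109 cell line (Homo sapiens) as the target, read by sulforhodamine B assay; a higher number here means a weaker inhibitor, a lower number a stronger inhibitor. Compound 1 gives 4090 nM, and compound 2 gives 4970 nM. Compound 2 holds the highest of the two numbers, yet its nearest neighbour, compound 1, lies so close that the two cannot be told apart from repeat measurements, so no order follows from them. Compound 3, `O=C1C=C(Nc2ccc(Br)cc2)C(=O)c2c1nc1n2[C@H]2OC[C@@H](O)[C@H]2OC1`, has not yet been measured in this assay. It differs from compound 2 in one place: bromo in place of hydrogen on an aromatic carbon. Going by the values given here, no step between measured compounds shows how such an exchange plays out in this assay, so the expectation rests only on how near compounds 1 and 2 sit. A small step toward a lower number is expected, a 1.7-fold lower number from compound 2 to compound 3 (0.22 log units; within the scatter), though one that may not exceed the scatter. Compound 3 is estimated at 3000 nM, within 1200 nM to 8000 nM.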

Compound 3, half-maximal inhibitory concentration: 2850 nM
The estimate for compound 3 lay 1.1-fold (0.02 log units) above the measured number, and the stated range covers the measured number.
By their numbers in this assay, from the lowest: compounds 3, 1 and 2 (each within the scatter of the next).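

In this assay, going by these compounds alone, bromo in place of hydrogen on the aromatic carbon para to a large group gives a 1.7-fold lower number from compound 2 to compound 3 (0.24 log units; within the scatter), the first step at this position between compounds that differ in one place. This exchange of anilino to (4-bromophenyl)amino therefore adds a heavy atom to the ring without moving the number beyond what repeat measurements could separate, so it gives no clear sign that this position affects the reading in either direction. No measurement shown bears on why the step is this size. As far as these compounds go, whether a different group at this position, such as an amine, a methoxy group or a carboxylic acid, would produce a step beyond the scatter stays open. Also open, from the compounds shown here alone, is whether fluoro or chloro would behave as bromo does here.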